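A few compounds are considered here, and "the series" means these few. Any claim that something is new, unique, unknown or untested is made for them only; others in the source may bear on it.

Compound 1, `c1cc([C@H]2CC[C@]3(CC2)OOC2(O3)C3CC4CC(C3)CC2C4)ccc1OCC1CCNCC1`: in a physicochemical assay for solubility, read by nephelometry, measured as kinetic solubility, with a stated time of 30 min (a higher number here means a more soluble compound, a lower number a less soluble compound), compound 1 gives 12.5 ug/mL.
Compound 2, `O[C@H]1CC[C@H](NCCCOc2ccc([C@H]3CC[C@]4(CC3)OOC3(O4)C4CC5CC(C4)CC3C5)cc2)CC1`: compound 2 gives > 100 ug/mL, which is a limit of the assay rather than a number.

Within the data shown here, compound 1 thus holds the only number among the values shown; the other value is a limit, (the limit of > 100 ug/mL in this assay, at which 1 of the 2 values shown sits). Compound 3, `CC1(C)CC(O)(COc2ccc([C@H]3CC[C@]4(CC3)OOC3(O4)C4CC5CC(C4)CC3C5)cc2)CC(C)(C)N1`, differs from compound 1 by 4-hydroxy-2,2,6,6-tetramethylpiperidin-4-yl in place of piperidin-4-yl on a saturated chain carbon bound to an oxygen on an aromatic ring. Among the measured compounds shown here, one measured step bears on this place: an at least 8.0-fold higher number from compound 1 to compound 2 (0.90 log units; beyond the scatter), a clear rise. For the measured compounds named here, a rise is therefore expected for compound 3 as well, a 2.8-fold higher number from compound 1 to compound 3 (0.45 log units; beyond the scatter), though the entering group is not the one seen in compound 2, so the size is uncertain. Compound 3 is estimated at 35 ug/mL, between 12 ug/mL and 100 ug/mL.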

Compound 3, solubility: > 100 ug/mL
Compound 3: a limit, no number; the forecaster's own chance of this, stated with the estimate: 25%; at least 2.8-fold (0.45 log units) between middle value and limit.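

In this assay, 4-hydroxy-2,2,6,6-tetramethylpiperidin-4-yl in place of piperidin-4-yl gives an at least 8.0-fold higher number from compound 1 to compound 3 (0.90 log units; beyond the scatter), so a second, different entering group also brings a rise at this place. From the compounds shown here alone, compound 3 sits at a limit of the assay, so the full size of this step stays unknown. The step from compound 2 to compound 3 cannot be read, because both values are limits: the limit of > 100 ug/mL in this assay, at which 2 of the 3 values shown sit.

Whether the hydroxy group or the methyl groups account for the rise stays open. So does the effect of a carboxylic acid or a longer chain on this saturated chain carbon.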